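Thiourea Analogue of a Urea Pair Awaits Its Affinity Measurement

A few compounds are considered here, and "the series" means these few. Any claim that something is new, unique, unknown or untested is made for them only; others in the source may bear on it.

Of the compounds shown here, three have been measured in an assay on isolated protein for binding affinity to stress-70 protein, mitochondrial (Homo sapiens); a lower number here means tighter binding, a higher number weaker binding. Compound 1, `CN1c2ccc(NC(=O)Nc3ccc([N+](=O)[O-])cc3)cc2C(C)(C)C(O)C1(C)C`, gives 1600 nM in this assay. Compound 2, `CN1c2ccc(NC(=S)Nc3ccc([N+](=O)[O-])cc3)cc2C(C)(C)C(O)C1(C)C`, gives 2300 nM in this assay; the difference between the core of compound 1 and the core of compound 2 is not broken down here, and the two values lie within the scatter of each other. Compound 3, `CN1c2ccc(NC(=O)Nc3ccc(C(F)(F)F)cc3)cc2C(C)(C)C(O)C1(C)C`, gives 700 nM in this assay.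

Compound 1 and compound 3 differ by one change, (trifluoromethyl in place of nitro on an aromatic carbon), and this change made a step of a 2.3-fold lower number from compound 1 to compound 3 (0.36 log units; beyond the scatter).

Compound 4, `CN1c2ccc(NC(=S)Nc3ccc(C(F)(F)F)cc3)cc2C(C)(C)C(O)C1(C)C`, has not yet been measured in this assay. It stands to compound 2 as compound 3 stands to compound 1: the difference is trifluoromethyl in place of nitro on an aromatic carbon, and the place of the change is described in the same words in both pairs, so it is the same change. On the strength of the step from compound 1 to compound 3, which was a 2.3-fold lower number from compound 1 to compound 3 (0.36 log units; beyond the scatter), the step from compound 2 to compound 4 is expected to be about a 2.3-fold lower number from compound 2 to compound 4 (0.36 log units; beyond the scatter) in this assay. This rests on a single earlier instance of the change, so the expectation is loose. For compound 4 the estimated value in this assay is therefore 1000 nM, with the expected range running from 450 nM to 2300 nM.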

Compound 4, dissociation constant: 2300 nM
Compound 4: middle estimate off by 2.3-fold (0.36 log units), on the low side, within the range that was stated.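

In this assay, putting trifluoromethyl in place of nitro on the core of compound 2 gave no change at the digits printed from compound 2 to compound 4 (within the scatter). Taken alone, this step might suggest that the change carries less well onto this core than onto the core of compound 1, yet the gap between the two steps is no larger than the scatter allows, so the pair gives no ground for saying that the change behaves differently on the two cores: the same change on two cores in this assay, a 2.3-fold lower number (0.36 log units; beyond the scatter) from compound 1 to compound 3 and no change at the digits printed (within the scatter) from compound 2 to compound 4, 2.3-fold (0.36 log units) apart, within the scatter of two such steps

Going by these compounds alone, this does not show that the change carries over unaltered either, since each core supplies only one pair, with one step beyond the scatter and the other within it, and two such steps can neither establish a shared effect nor reveal a dependence on the core.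

The compounds shown offer only nitro and trifluoromethyl at this place on the aromatic ring, so it remains open how a nitrile, a chlorine atom, a methoxy group or an amine would read there on either core. Further matched pairs carrying such groups on both cores would be needed to tell whether steps on the two cores run together or apart.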